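The compounds below may be only part of what the source reports. "The series", "measured", "known", "first", "only" and "open" are said of these compounds alone.

Measured compounds:
- compound 1, `COC(=O)c1ccccc1-c1cnc(C(=O)CCCCCCc2ccccc2)o1`: in an assay (Rattus norvegicus) for inhibition of Fatty-acid amide hydrolase 1 (Homo sapiens) (on this read-out lower numbers stand for stronger inhibition and higher numbers for weaker inhibition), compound 1 gives 60 nM
- compound 2, `N#Cc1cnc(C(O)CCCCCCc2ccccc2)o1`: in this assay compound 2 gives 4200 nM

Compound 2 stands at the higher of the two numbers, far from compound 1; the two differ in more than one place, so only their two values can be compared, and the gap between them is well beyond the usual scatter. Compound 3, `O=C(O)c1ccc(-c2cnc(C(O)CCCCCCc3ccccc3)o2)nc1`, keeps the alcohol and the seven-carbon chain of compound 2 and changes one group: 5-carboxypyridin-2-yl in place of cyano on an aromatic carbon. Compound 1 carries an aromatic group at this same position together with a ketone, and that combination gives the low number seen. With the alcohol retained, only a modest gain is expected here, and the step in this assay is estimated as a 2.8-fold lower number from compound 2 to compound 3 (0.45 log units; beyond the scatter). For compound 3 the expected value is 1500 nM, with a plausible range from 300 nM to 8000 nM.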

Compound 3, inhibition constant: 45000 nM
Estimate against measurement, compound 3: 30-fold (1.48 log units) below, outside the stated range (above it).
By their numbers in this assay, from the lowest: compound 1; then compound 2; then compound 3.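

In this assay, placing 5-carboxypyridin-2-yl in place of cyano on this aromatic carbon gives an 11-fold higher number from compound 2 to compound 3 (1.03 log units; beyond the scatter), so with the alcohol kept, this larger group weakens inhibition rather than strengthening it. An aromatic ring at this position therefore does not bring a low number by itself, and the position is sensitive to what it carries. Nothing in the data shown explains this loss.

As far as these compounds go, whether the loss follows the carboxylic acid or the pyridine ring stays open, and a methyl ester in place of the acid on the same ring would help separate the two. Also open, from the compounds shown here alone, is how a ketone in place of the alcohol would behave with 5-carboxypyridin-2-yl at this position.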